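From 2,5-dioxoimidazolidin-1-yl to methanesulfonamido: expected cytotoxicity

The compounds below may be only part of what the source reports. "The series", "measured", "known", "first", "only" and "open" are said of these compounds alone.

Compound 2 `O=C1CNC(=O)N1C[C@H]1CN(c2ccc(-n3cc(-c4ccccn4)cn3)c(F)c2)C(=O)O1` is one of three compounds tested in an ADME assay on L02 cells (Homo sapiens) for cytotoxicity, read by MTT assay, with a stated time of 48 h; a lower number here means a stronger inhibitor, a higher number a weaker inhibitor. In that assay compound 2 reached only the limit of > 400 ug/mL, which is a limit of the assay and not a number. Compound 1 `O=C1O[C@@H](CN2CCC(c3ccc(F)cc3)CC2)CN1c1ccc(-n2cc(-c3ccccn3)cn2)c(F)c1` likewise stopped at the limit of > 400 ug/mL. Within the data shown here, compound 3 `CCC(=O)NC[C@H]1CN(c2ccc(-n3cc(-c4ccccn4)cn3)c(F)c2)C(=O)O1` is the one compound with a measured number, giving 204 ug/mL in this assay. Among the measured compounds shown here, the only step between directly comparable compounds is an at least 1.9-fold lower number from compound 2 to compound 3 (0.29 log units; that floor lies within the scatter); because the limit of > 400 ug/mL in this assay, at which 2 of the 3 values shown sit, holds two of the three values, that step cannot be judged in full and its floor sits within the scatter. Compound 4 `CS(=O)(=O)NC[C@H]1CN(c2ccc(-n3cc(-c4ccccn4)cn3)c(F)c2)C(=O)O1` differs from compound 2 in one place: methanesulfonamido in place of 2,5-dioxoimidazolidin-1-yl on a saturated chain carbon bound to a saturated ring carbon. For the measured compounds named here, the single comparable step, from compound 2 to compound 3, did not show a shift beyond the scatter, so no shift beyond the scatter is expected here either. The step expected for compound 4 is therefore a number no higher from compound 2 to compound 4 (the limit leaves the size open). Compound 4 is expected to give about 400 ug/mL in this assay, within a range from 150 ug/mL to 1000 ug/mL, with a fair chance that again only a limit is reported.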

Compound 4, half-maximal inhibitory concentration: > 400 ug/mL
Compound 4 was reported as a limit; the forecaster's own chance of this, stated with the estimate: 60%; the middle value sits exactly at the limit.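

In this assay, among these compounds, compound 4 is reported only as a limit, which shows that a group with no ring at this place can also end at a limit; until now compound 3 was the only compound with such a group, and it gave a measured number. Methylsulfonyl in place of propanoyl on an amine nitrogen gives an at least 1.9-fold higher number from compound 3 to compound 4 (0.29 log units; that floor lies within the scatter) and so does not establish a change beyond the scatter. The step between compound 2 and compound 4 cannot be read, because both values are limits: the limit of > 400 ug/mL in this assay, at which 3 of the 4 values shown sit.

Among the compounds shown here, compound 3 remains the only compound with a measured number, so the true size of any step here stays open. As far as these compounds go, whether a free amine or a longer chain such as butanoyl on the same nitrogen would give a measured number also remains open.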